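The source may report more compounds than this note shows. Statements on the series, on what has been measured and on what is new or still open speak of the compounds shown alone.

Measured compounds in an ADME assay on MT4 cells (Homo sapiens) for cytotoxicity, read by MTT assay, with a stated time of 5 days; a higher number here means that more compound is tolerated, a lower number that less compound is tolerated:
compound 1 `Cc1cccc(NC(=O)CSc2snnc2-c2ccc(Br)cc2Br)c1C` gives 241000 nM
compound 2 `O=C(CSc1snnc1-c1ccc(Br)cc1Br)Nc1ccccc1Br` gives > 221000 nM, which is a limit of the assay
compound 3 `Cc1ccc(NC(=O)CSc2snnc2-c2ccc(Br)cc2Br)c(Br)c1` gives > 216000 nM, which is a limit of the assay

Among the measured compounds shown here, compound 1 holds the only number among the three values shown; the other two are limits. Compound 4 `Cc1ccc(NC(=O)CSc2snnc2-c2ccc(Br)cc2Br)cc1` differs from compound 1 in this way: 4-methylphenyl in place of 2,3-dimethylphenyl on an amide-type nitrogen. The measured steps that bear on this change are a step that the limit leaves unreadable from compound 1 to compound 2 and a step that the limit leaves unreadable from compound 1 to compound 3, both left unreadable in size by the limits. Since compound 4 likewise alters only the group on the amide-type nitrogen, the step of a 1.0-fold lower number from compound 1 to compound 4 (0.02 log units; within the scatter) is expected to stay within the scatter, with a fair chance that this assay again reports only a limit. Compound 4 is therefore estimated at 230000 nM, between 120000 nM and 420000 nM.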

Compound 4, half-maximal cytotoxic concentration: 24000 nM
The estimate for compound 4 lay 9.6-fold (0.98 log units) above the measured number; the measured number lies below the stated range.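

In this assay, among the compounds shown here, a 10-fold lower number from compound 1 to compound 4 (1.00 log units; beyond the scatter) is the first readable step at the amide-type nitrogen, and it shows that changing this group alone can move the number beyond the scatter. For the compounds shown here, with hydrogen in place of bromo as the single change, the result is an at least 9.0-fold lower number from compound 3 to compound 4 (0.95 log units; beyond the scatter), and an at least 9.2-fold lower number from compound 2 to compound 4 (0.96 log units; beyond the scatter) points the same way; both rest on limits of the assay, while the steps among compound 1, compound 2 and compound 3 cannot be read. The compounds shown leave open whether a plain phenyl or a 4-aminophenyl group on that nitrogen would also give a lower number.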